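This account rests on a few compounds, and the source may have more. Where it says the series, first, only, none or still open, it means among the compounds named here.

Notes on the series around compound 1 `COc1cc2c(cc1O)C/C(=C\c1cc(C)c(O)c(C)c1)C2=O`. In a functional assay on Jurkat cells (Homo sapiens) for antiproliferative activity, read by MTT assay (on this read-out higher numbers stand for weaker inhibition and lower numbers for stronger inhibition), compound 1 gives 530 nM, the lowest of the three numbers recorded so far. Compound 2 `COc1cc2c(c([N+](=O)[O-])c1O)C/C(=C\c1cc(C)c(O)c(C)c1)C2=O` gives 9300 nM in this assay, and compound 3 `COc1cc2c(c(N)c1O)C/C(=C\c1cc(C)c(O)c(C)c1)C2=O` gives 30000 nM. The steps are an 18-fold higher number from compound 1 to compound 2 (1.24 log units; beyond the scatter) and a 57-fold higher number from compound 1 to compound 3 (1.75 log units; beyond the scatter); between the two substituted analogues the step is a 3.2-fold higher number from compound 2 to compound 3 (0.51 log units; beyond the scatter).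

Compound 4 `COc1ccc2c(c1)C(=O)/C(=C/c1cc(C)c(O)c(C)c1)C2` differs from compound 1 by hydrogen in place of hydroxy on an aromatic carbon. Going by the values given here, no measured step removes a group from the shared core; the two steps that exist both add a group to that ring and both cost a large amount, so they bear on the new step only in showing that changes on this ring have not been tolerated. The removal of the hydroxy is a smaller change than either addition, and the estimate therefore sits between no change and the smaller of the two measured losses. Compound 4 is expected to give 1500 nM in this assay, with a range from 400 nM to 6000 nM, which means an expected step of a 2.8-fold higher number from compound 1 to compound 4 (0.45 log units; beyond the scatter).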

Compound 4, half-maximal inhibitory concentration: > 50000 nM
Compound 4: a limit, no number (the forecaster's own chance of this, stated with the estimate: 5%); middle value at least 33-fold (1.52 log units) from the limit.
By their numbers in this assay, from the lowest: compound 1; then compound 2; then compound 3. At a limit, above all of these: compound 4.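

In this assay, the reading for compound 4 is a limit and not a number: the limit of > 50000 nM in this assay, at which 1 of the 4 values shown sits. The change of hydrogen in place of hydroxy, on an aromatic carbon ortho to a methoxy group, gives an at least 94-fold higher number from compound 1 to compound 4 (1.97 log units; beyond the scatter), so this position does not need an added group to lose activity, and removal of the hydroxy alone is enough to reach the limit. Compound 2 keeps this hydroxy and gives 9300 nM, and compound 3 also keeps it and gives 30000 nM, so across these four compounds the hydroxy goes with a readable number even when a nitro or amino group is added to the same ring. Going by these compounds alone, compound 4, the one without it, is the only compound at the limit.

On these data alone, the true size of the step stays open, since the reading for compound 4 fixes only its lower end. Also open, as far as these compounds go, is whether anything other than hydroxy can stand at this position, for example a fluorine atom, a hydroxymethyl group or a carboxylic acid, and whether the hydroxy on the other aromatic ring matters to the same degree.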